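The source may report more compounds than this note shows. Statements on the series, on what has been measured and on what is new or still open speak of the compounds shown alone.

Measured compounds:
Compound 1 `CNC(=O)c1ccccc1Oc1nc(Nc2cccc(Br)c2)ncc1Br` gives 10600 nM in a functional assay on A549 cells (Homo sapiens) for antiproliferative activity, read by MTT assay, with a stated time of 24 h; a higher number here means a weaker inhibitor, a lower number a stronger inhibitor.
Compound 2 `CNC(=O)c1ccccc1Oc1nc(Nc2ccc(C)cc2C)ncc1Br` gives 27300 nM in this assay.

Within the data shown here, compound 2 stands highest of the two numbers in this assay, with compound 1 as its only neighbour. Among the measured compounds shown here, the single measured step is a 2.6-fold higher number from compound 1 to compound 2 (0.41 log units; beyond the scatter), a modest rise that lies beyond the scatter.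

Compound 3 `CNC(=O)c1ccccc1Oc1nc(Nc2cccc(OC)c2)ncc1Br` is not yet measured. It differs from compound 2 in one place: 3-methoxyphenyl in place of 2,4-dimethylphenyl on a nitrogen on an aromatic ring. For the measured compounds named here, the one step that bears on this change is a 2.6-fold higher number from compound 1 to compound 2 (0.41 log units; beyond the scatter), in which the same 2,4-dimethylphenyl group entered in place of a 3-bromophenyl group and the number rose modestly. Removing that group again in favour of 3-methoxyphenyl is expected to move the number back somewhat toward that of compound 1, though the two entering groups are not the same. Compound 3 is therefore estimated at 14000 nM in this assay, within 5000 nM to 40000 nM, an expected step of a 2.0-fold lower number from compound 2 to compound 3 (0.29 log units; within the scatter).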

Compound 3, half-maximal inhibitory concentration: 6230 nM
Estimate against measurement, compound 3: 2.2-fold (0.35 log units) above; measured number inside the range.
By their numbers in this assay, from the lowest: compounds 3 and 1 (each within the scatter of the next); then compound 2.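

In this assay the exchange of 2,4-dimethylphenyl for 3-methoxyphenyl on the nitrogen gives a 4.4-fold lower number from compound 2 to compound 3 (0.64 log units; beyond the scatter), a modest step beyond the scatter, so compound 2 now stands apart as the weakest of the three compounds. Methoxy in place of bromo on an aromatic carbon gives a 1.7-fold lower number from compound 1 to compound 3 (0.23 log units; within the scatter), which lies within the scatter, so this change separates compound 1 and compound 3 by no reliable margin. Nothing available explains why these groups on the nitrogen give these numbers.

Compound 2 differs from the other two compounds in both the kind and the placing of its groups, so the compounds shown cannot tell which of these sets it apart. Going by these compounds, how an amine, a carboxylic acid or a longer alkoxy chain on this ring would read in this assay also remains open.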